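A few compounds are considered here, and "the series" means these few. Any claim that something is new, unique, unknown or untested is made for them only; others in the source may bear on it.

Values in a functional assay on HeLa cells (Homo sapiens) for inhibition, read by CCK-8 assay, with a stated time of 48 h; a lower number here means a stronger inhibitor, a higher number a weaker inhibitor
compound 1 `COc1cc(-c2ccnc3cc(-c4ccc(C)cc4)nn23)cc(OC)c1OC` gives 21 nM
compound 2 `COc1cc(-c2ccnc3cc(-c4ccc5cc[nH]c5c4)nn23)cc(OC)c1OC` gives 125 nM
compound 3 `COc1cc(-c2ccnc3cc(-c4ccc(N(C)C)cc4)nn23)cc(OC)c1OC` gives 378 nM

Compound 3 at 378 nM has the highest number of the three and is the weakest inhibitor here. Compound 4 `COc1cc(-c2ccnc3cc(-c4ccc5ccn(C)c5c4)nn23)cc(OC)c1OC` has not been measured yet. It carries 1-methyl-1H-indol-6-yl in place of 4-(dimethylamino)phenyl on an aromatic carbon of the shared core 1-methyl-1H-indol-6-yl in place of 4-(dimethylamino)phenyl on an aromatic carbon and nothing else changes. The closest guide is compound 2, which has 1H-indol-6-yl and shows a 3.0-fold higher number from compound 2 to compound 3 (0.48 log units; beyond the scatter) as its measured step. The step of an 18-fold higher number from compound 1 to compound 3 (1.26 log units; beyond the scatter) shows how far a change at this place can move the number. Going by the values given here, no measured compound carries the 1-methyl group, so the estimate stays wide. In this assay the expected change is a modest to large step down, a 5.4-fold lower number from compound 3 to compound 4 (0.73 log units; beyond the scatter) as estimated. The estimated value for compound 4 is 70 nM with an expected range from 15 nM to 300 nM in this measurement.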

Compound 4, half-maximal inhibitory concentration: 187 nM
Compound 4: the middle estimate sits 2.7-fold (0.43 log units) below what was measured; the measured number falls inside the stated range.
By their numbers in this assay, from the lowest: compound 1; then compounds 2 and 4 (each within the scatter of the next); then compound 3.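

In this assay, methyl in place of hydrogen on the aromatic nitrogen gives a 1.5-fold higher number from compound 2 to compound 4 (0.17 log units; within the scatter), so the hydrogen on that nitrogen can be replaced without a readable change. The methylated group still keeps its edge over 4-(dimethylamino)phenyl, with a 2.0-fold lower number from compound 3 to compound 4 (0.31 log units; beyond the scatter), yet it falls well short of 4-methylphenyl, with an 8.9-fold higher number from compound 1 to compound 4 (0.95 log units; beyond the scatter). Nothing available explains these differences.

From the compounds shown here alone, what a longer chain or an amine-bearing chain on that aromatic nitrogen would do remains open. So does whether 4-ethylphenyl at this place could match compound 1.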